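A few compounds are considered here, and "the series" means these few. Any claim that something is new, unique, unknown or untested is made for them only; others in the source may bear on it.

Compound 3 `C#Cc1cccc(N2C(=O)CSC2c2cccc(C(=O)NCCCCc3ccccc3)c2)c1` gives 1820 mL.min-1.g-1 in an ADME assay on microsomes from liver (Rattus norvegicus) for metabolic stability, read by LC-MS, using NADPH, with a stated time of 10 min, tested at 0.1 uM; a lower number here means slower removal, a higher number faster removal of the compound. Compound 1 `COc1ccc(F)cc1N1C(=O)CSC1c1cccc(C(=O)NCCCCn2cccn2)c1` gives 1470 mL.min-1.g-1, which lies within the usual scatter of compound 3, so these two stand level at the top of the three measured numbers. Compound 2 `O=C(NCCCCc1ccccc1)c1cccc(C2SCC(=O)N2c2cccc(-c3c[nH]nn3)c2)c1` gives 742 mL.min-1.g-1, clearly lower than compound 3.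

The next compound, compound 4 `O=C(NCCCCc1ccccc1)c1cccc(C2SCC(=O)N2c2ccc(C3CC3)cc2)c1`, carries 4-cyclopropylphenyl in place of the 3-ethynylphenyl of compound 3 on an amide-type nitrogen in a ring (4-cyclopropylphenyl in place of 3-ethynylphenyl on an amide-type nitrogen in a ring). A triple bond outside the aromatic ring leaves, and a three-membered non-aromatic ring of carbon enters.

For the measured compounds named here, only one measured step bears directly on this part of the molecule: a 2.5-fold higher number from compound 2 to compound 3 (0.39 log units; beyond the scatter). It is modest, and it swaps 1H-1,2,3-triazol-4-yl for ethynyl, so it tells only what happens when ethynyl enters, not what happens when it is replaced by cyclopropyl. Compound 1 differs from compound 3 in more than one place and offers no clean comparison. Going by the values given here, with no measured compound carrying a cyclopropyl group, no clear direction can be argued, and the expected outcome in this assay is no change beyond the scatter, with a 1.1-fold lower number from compound 3 to compound 4 (0.06 log units; within the scatter) as the estimated step. For compound 4 the estimated value is 1600 mL.min-1.g-1, with an expected range from 850 mL.min-1.g-1 to 3000 mL.min-1.g-1.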

Compound 4, intrinsic clearance in microsomes: 2280 mL.min-1.g-1
Beside the measured number, compound 4's estimate is 1.4-fold (0.15 log units) below it; the measured number falls inside the stated range.
By their numbers in this assay, from the lowest: compounds 2, 1, 3 and 4 (each within the scatter of the next, the first and the last beyond it).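

In this assay, putting 4-cyclopropylphenyl in place of 3-ethynylphenyl on the amide-type nitrogen in a ring gives a 1.3-fold higher number from compound 3 to compound 4 (0.10 log units; within the scatter), so two groups with different substituents, attached at different ring positions, leave this read-out level. Set against the triazole-bearing group of compound 2, the new group gives a 3.1-fold higher number from compound 2 to compound 4 (0.49 log units; beyond the scatter), a step of modest size that runs the same way as a 2.5-fold higher number from compound 2 to compound 3 (0.39 log units; beyond the scatter), so among the three compounds that vary only at this nitrogen, compound 2 alone stands apart, while the two compounds whose groups hold only carbon stay together. Nothing available explains why the triazole-bearing group goes with the lower number.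

Compound 4 changes both the substituent and its place on the phenyl ring, so a 3-cyclopropylphenyl group would be needed to separate these two changes. From the compounds shown here alone, it also remains open whether the lower number belongs to the triazole alone or would also appear with other groups on this phenyl ring, such as an amine or a carboxylic acid.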